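Carbonyl-side heteroaryl swap: compound 3 to compound 4

This account rests on a few compounds, and the source may have more. Where it says the series, first, only, none or still open, it means among the compounds named here.

The series keeps one amide fixed and varies the aryl group on the other carbonyl carbon. Compound 1 `CN(C)c1cccc(C(=O)N[C@H]2CCC[C@H](NC(=O)c3cccc(Cl)c3)C2)c1` carries a 3-(dimethylamino)phenyl there. In a functional assay on HEK293 cells for antagonist activity at metabotropic glutamate receptor 5 (Homo sapiens), read by FLIPR and calcium flux (on this read-out lower numbers stand for stronger inhibition and higher numbers for weaker inhibition), compound 1 gives > 10000 nM, which is a limit of the assay and not a number (the limit of > 10000 nM in this assay, at which 1 of the 3 values shown sits). Compound 2 `O=C(N[C@H]1CCC[C@H](NC(=O)c2cnccn2)C1)c1cccc(Cl)c1` carries pyrazin-2-yl and in this assay compound 2 gives 1370 nM. Compound 3 `O=C(N[C@H]1CCC[C@H](NC(=O)c2cccc(Cl)c2)C1)c1ccncc1` carries pyridin-4-yl and in this assay compound 3 gives 300 nM, the lowest of the two numbers shown; its nearest neighbour is compound 2, with a 4.6-fold lower number from compound 2 to compound 3 (0.66 log units; beyond the scatter), and an at least 33-fold lower number from compound 1 to compound 3 (1.52 log units; beyond the scatter) separates it from the limit of compound 1.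

Compound 4 `Cc1cccc(C(=O)N[C@H]2CCC[C@H](NC(=O)c3cccc(Cl)c3)C2)n1` is the next step: 6-methylpyridin-2-yl in place of pyridin-4-yl on a carbonyl carbon. The measured steps on this carbonyl carbon, an at least 7.2-fold lower number from compound 1 to compound 2 (0.86 log units; beyond the scatter), an at least 33-fold lower number from compound 1 to compound 3 (1.52 log units; beyond the scatter) and a 4.6-fold lower number from compound 2 to compound 3 (0.66 log units; beyond the scatter), all changed the aryl group outright and all moved the number beyond the scatter, but none of them shifts the ring nitrogen or adds a methyl on the same ring, so they bound the change only loosely. Given that every change away from pyridin-4-yl shown so far raised the number, compound 4 is expected to give a number above compound 3 by a modest step, a 3.0-fold higher number from compound 3 to compound 4 (0.48 log units; beyond the scatter), and the estimate for compound 4 is 900 nM, within 200 nM to 4000 nM.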

Compound 4, half-maximal inhibitory concentration: 290 nM
Beside the measured number, compound 4's estimate is 3.1-fold (0.49 log units) above it; low and high end bracket the measured number.
By their numbers in this assay, from the lowest: compounds 4 and 3 (each within the scatter of the next); then compound 2. At a limit, above all of these: compound 1.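

Notes on the carbonyl-side aryl group: in this assay, 6-methylpyridin-2-yl and pyridin-4-yl cannot be told apart on this carbonyl carbon (a 1.0-fold lower number from compound 3 to compound 4 (0.01 log units; within the scatter)), so among the groups shown pyridin-4-yl is no longer the only one that reaches this level. The gain over pyrazin-2-yl also holds for the new group (a 4.7-fold lower number from compound 2 to compound 4 (0.67 log units; beyond the scatter)), which places both pyridines clearly ahead of that ring at this position. Compound 1 remains at a limit of the assay and not a number, so the step to the new group gives only a bound on its size (an at least 34-fold lower number from compound 1 to compound 4 (1.53 log units; beyond the scatter)).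

Nothing measured in this set bears on why the two pyridines read alike. Going by these compounds, the separate shares of the methyl and of the ring nitrogen remain open, and plain pyridin-2-yl, 6-ethylpyridin-2-yl or 6-methylpyridin-3-yl on the same carbonyl carbon would be needed to tell them apart.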